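Replacing ethoxy on the carbonyl carbon of compound 2

This account rests on a few compounds, and the source may have more. Where it says the series, first, only, none or still open, it means among the compounds named here.

Within the data shown here, only two compounds on the shared core have numbers so far. In a functional assay on the whole organism for inhibition, with Mus musculus as the target (a lower number here means that less compound is needed, a higher number that more compound is needed for the effect), compound 1 (`CCOC(=O)Nc1cccc2c1CN(C)CC2c1ccccc1`) gives 3.2 mg/kg, and compound 2 (`CCOC(=O)Nc1cccc2c1CN(C)CC2c1ccc(Cl)cc1`) gives 4.8 mg/kg. Chloro in place of hydrogen on an aromatic carbon makes up a 1.5-fold higher number from compound 1 to compound 2 (0.18 log units; within the scatter), so compound 2 stands level with the only other measured compound.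

Compound 3 (`CCCCNCC(=O)Nc1cccc2c1CN(C)CC2c1ccc(Cl)cc1`) keeps the chloro and takes (butylamino)methyl in place of ethoxy on a carbonyl carbon. The same difference reads as ethoxycarbonyl to ((butylamino)methyl)carbonyl.

Among the measured compounds shown here, no measured compound varies the group on this carbonyl carbon. For the measured compounds named here, the single measured step, a 1.5-fold higher number from compound 1 to compound 2 (0.18 log units; within the scatter), lies at a different place and gives only a weak guide, so the size of the new step stays open. The exchange is larger than a single chloro for hydrogen, and a modest move to a higher number in this assay is expected, though that direction is a judgement and no measurement supports it. The estimated change is a 1.7-fold higher number from compound 2 to compound 3 (0.22 log units; within the scatter). For compound 3 the expected value is 8 mg/kg, with an estimated range of 2 mg/kg to 30 mg/kg.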

Compound 3, dose for half-maximal effect: 13.5 mg/kg
Estimate against measurement, compound 3: 1.7-fold (0.23 log units) below; low and high end bracket the measured number.
By their numbers in this assay, from the lowest: compounds 1 and 2 (each within the scatter of the next); then compound 3.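

In this assay, among these compounds, (butylamino)methyl in place of ethoxy on a carbonyl carbon gives a 2.8-fold higher number from compound 2 to compound 3 (0.45 log units; beyond the scatter) and so provides the first step beyond the scatter. This position therefore responds to the exchange, whereas chloro in place of hydrogen on an aromatic carbon, with a 1.5-fold higher number from compound 1 to compound 2 (0.18 log units; within the scatter), gave no readable change. The step alters chain length and atom types at once, so this single pair cannot show which difference carries the higher number, and no measurement on these compounds offers an explanation.

Open, from the compounds shown here alone, is whether a shorter (methylamino)methyl, a (dimethylamino)methyl or a plain propyl chain on the carbonyl carbon would stay near compound 2 at 4.8 mg/kg or move towards the higher number. Also open, going by these compounds, is how hydrogen in place of chloro on the aromatic carbon reads when (butylamino)methyl sits on the carbonyl carbon, and so whether the two changes act independently.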